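Anilide to pyridyl amide in the paw edema series

The source may hold more compounds than are shown below. What is called first, only, known or untested is meant among the compounds shown, and "the series" means these compounds.

Working notes. For the measured compounds named here, compound 1 `COc1cc2c(cc1OC)C(CC(=O)Nc1ccccc1)CC2` gives 31.3% in a functional assay on the whole organism (strain Wistar) for inhibition, with Rattus norvegicus as the target, read by paw edema, with a stated time of 1 h, at a dose of 100 mg/kg (a lower number here means less inhibition, a higher number more inhibition at the dose given (going by the name of the read-out)), the second highest of the three numbers measured so far; nearest stands compound 3 `COc1cc2c(cc1OC)C(CC(=O)Nc1ccc(C)cc1)CC2` at 34.4%, furthest compound 2 `COc1cc2c(cc1OC)C(CC(=O)Nc1ccccc1C)CC2` at 21.9%, and both of those gaps lie within the scatter. Compound 4 `COc1cc2c(cc1OC)C(CC(=O)Nc1ccncc1)CC2` differs from compound 1 by pyridin-4-yl in place of phenyl on an amide-type nitrogen. Going by the values given here, no measured step exchanges the ring itself; the only steps that touch this ring are a number 9.4 percentage points lower from compound 1 to compound 2 (within the scatter) and a number 3.1 percentage points higher from compound 1 to compound 3 (within the scatter), both within the scatter, while a number 12.5 percentage points higher from compound 2 to compound 3 (beyond the scatter) is the single modest step beyond it. On this basis no step beyond the scatter is expected, and the step is estimated as a number 1.3 percentage points lower from compound 1 to compound 4 (within the scatter). In this assay compound 4 is therefore expected to give about 30%, within 15% to 45%.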

Compound 4, a percentage reported as inhibition, in the whole organism at one dose (the size of the read-out at that dose, not a potency): 42.2%
Estimate against measurement, compound 4: 12.2 percentage points below; the range from low to high includes it.
By their numbers in this assay, from the lowest: compounds 2, 1, 3 and 4 (each within the scatter of the next, the first and the last beyond it).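

In this assay, pyridin-4-yl in place of phenyl on the amide-type nitrogen gives the first step from compound 1 beyond the scatter: a number 10.9 percentage points higher from compound 1 to compound 4 (beyond the scatter). The ring exchange also separates from 2-methylphenyl, a number 20.3 percentage points higher from compound 2 to compound 4 (beyond the scatter), but not from 4-methylphenyl, a number 7.8 percentage points higher from compound 3 to compound 4 (within the scatter). Nothing measured here bears on the cause of these steps.

Open, on these data alone, is whether the result depends on where the ring nitrogen sits, which pyridin-3-yl and pyridin-2-yl would test. Also open, as far as these compounds go, is how a carboxylic acid or an amine on this ring would read.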